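Chloro in place of hydroxy at compound 4

The compounds below may be only part of what the source reports. "The series", "measured", "known", "first", "only" and "open" are said of these compounds alone.

Measured in an ADME assay for permeability, using PAMPA, at pH 7.4 (on this read-out lower numbers stand for lower permeability and higher numbers for higher permeability), so far
- compound 1 `Cc1cc(NC(=O)Nc2ccccc2N)c2ccccc2n1` gives 300 10^-6 cm/s here
- compound 2 `Cc1cc(NC(=O)Nc2ccc(C(F)(F)F)cc2)c2ccccc2n1` gives 2 10^-6 cm/s here
- compound 3 `Cc1cc(NC(=O)Nc2ccc(O)cc2)c2ccccc2n1` gives 3 10^-6 cm/s here

Compound 3 is the starting point. Its number sits level with one neighbour and far under the other, with a 1.5-fold higher number from compound 2 to compound 3 (0.18 log units; within the scatter) on one side and a 100-fold lower number from compound 1 to compound 3 (2.00 log units; beyond the scatter) on the other. Compound 4 `Cc1cc(NC(=O)Nc2ccc(Cl)cc2)c2ccccc2n1` differs from compound 3 by chloro in place of hydroxy on an aromatic carbon and is chloro in place of hydroxy on an aromatic carbon. The first of those steps is also a swap on an aromatic carbon and bears directly on this change. The second exchanges a whole substituted phenyl group and offers little guidance. Expected here is no change at the digits printed from compound 3 to compound 4 (within the scatter) with no shift beyond the scatter in this assay overall. For compound 4 the estimate is 3 10^-6 cm/s with an expected range from 1 10^-6 cm/s to 10 10^-6 cm/s in this read-out.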

Compound 4, apparent permeability: 537 10^-6 cm/s
Compound 4: middle estimate off by 180-fold (2.25 log units), on the low side; measured number above the stated range.
By their numbers in this assay, from the lowest: compounds 2 and 3 (each within the scatter of the next); then compounds 1 and 4 (each within the scatter of the next).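

For the compounds shown here, at this aromatic carbon, the single group matters greatly in this assay: chloro in place of hydroxy gives a 180-fold higher number from compound 3 to compound 4 (2.25 log units; beyond the scatter), and chloro in place of trifluoromethyl gives a 270-fold higher number from compound 2 to compound 4 (2.43 log units; beyond the scatter), although the hydroxy and trifluoromethyl compounds had stood level. The 4-chlorophenyl group also matches the 2-aminophenyl group, with a 1.8-fold higher number from compound 1 to compound 4 (0.25 log units; within the scatter). Nothing available explains why chloro stands so far apart from the other two groups.

As far as these compounds go, whether fluoro, bromo or methyl at this place would follow chloro remains open. So does whether methoxy would stay level with hydroxy.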